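Notes on the N-substituent step from compound 3 to compound 4

The source may hold more compounds than are shown below. What is called first, only, known or untested is meant among the compounds shown, and "the series" means these compounds.

The series shares a common core carrying an amino group and a substituent on an aromatic nitrogen of the five-membered ring. Compound 1 `CC(C)n1nc(-c2cc(-c3ccccc3)on2)c2c(N)ncnc21` gives in an assay on TT cells for inhibition of proto-oncogene tyrosine-protein kinase receptor Ret variant C634W (Homo sapiens), read by MTT assay, with a stated time of 10 days (on this read-out higher numbers stand for weaker inhibition of growth and lower numbers for stronger inhibition of growth), only a limit, > 10000 nM. Compound 2 `CC(C)n1nc(/C=N/OCc2ccccc2)c2c(N)ncnc21` gives 9270 nM. Compound 3 `Nc1ncnc2c1c(-c1cc(C3CC3)on1)nn2C1CCOCC1` gives 940 nM, the lowest of the two numbers shown, with compound 2 the nearest at a gap beyond the scatter. One of the three values is a limit rather than a number, as noted in the limit of > 10000 nM in this assay, at which 1 of the 3 values shown sits.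

The unmeasured compound 4 `Cn1nc(-c2cc(C3CC3)on2)c2c(N)ncnc21` differs from compound 3 in one place: methyl in place of oxan-4-yl on an aromatic nitrogen. The change is a loss of the six-membered non-aromatic ring with its one hetero atom in favour of a single carbon atom, at the position given above; the 5-cyclopropyl-1,2-oxazol-3-yl group of compound 3 is kept. For the measured compounds named here, no measured pair in this set isolates this change, so the step is judged without a direct precedent. The much smaller group is expected to cost potency, a step beyond the scatter toward weaker inhibition of growth in this assay, estimated as a 3.2-fold higher number from compound 3 to compound 4 (0.50 log units; beyond the scatter). Compound 4 is therefore expected to give about 3000 nM, within a range of 800 nM to 12000 nM.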

Compound 4, concentration for 50% growth inhibition: 3510 nM
Beside the measured number, compound 4's estimate is 1.2-fold (0.07 log units) below it; the range from low to high includes it.
By their numbers in this assay, from the lowest: compound 3; then compound 4; then compound 2. At a limit, above all of these: compound 1.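

In this assay, for the compounds shown here, methyl in place of oxan-4-yl on an aromatic nitrogen is the first change that can be read in isolation, and it gives a 3.7-fold higher number from compound 3 to compound 4 (0.57 log units; beyond the scatter). With the 5-cyclopropyl-1,2-oxazol-3-yl group held constant, the substituent at this position therefore affects the read-out, with oxan-4-yl giving the lower number, although compound 4 still gives a measured number and not a limit. The available evidence concerns only the assay limit and does not bear on the reason for this step.

The step removes the ring and its oxygen together, so the compounds shown do not separate the contribution of the ring from that of the hetero atom; cyclohexyl in this position would keep the carbon ring without the oxygen, while a piperidine ring or a short chain such as ethyl would test other replacements. Compound 1 and compound 2 differ from compound 3 in more than one place, so they do not show how any other group on this nitrogen compares with oxan-4-yl or methyl.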